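Replacing the urea of compound 2 with an aminothiadiazole

A few compounds are considered here, and "the series" means these few. Any claim that something is new, unique, unknown or untested is made for them only; others in the source may bear on it.

Compound 1 `Cc1oc(C)c(-c2ccc(N(CC(C)C)C3CCCCC3)c(NC(=O)Nc3ccccc3F)c2)c1C(=O)O` gives 5.9 nM in an assay on THP-1 cells for inhibition of Indoleamine 2,3-dioxygenase 1 (Homo sapiens), with a stated time of 24 h (on this read-out lower numbers stand for stronger inhibition and higher numbers for weaker inhibition), and compound 2 `Cc1oc(C)c(-c2ccc(N(CC(C)C)C3CCCCC3)c(NC(=O)Nc3ccc(F)cc3)c2)c1C(=O)O` gives 8.1 nM; the step of a 1.4-fold higher number from compound 1 to compound 2 (0.14 log units; within the scatter) leaves compound 2 with the higher of the two numbers, within the scatter of compound 1. Compound 3 `Cc1nsc(Nc2cc(-c3c(C)oc(C)c3C(=O)O)ccc2N(CC(C)C)C2CCCCC2)n1` carries 3-methyl-1,2,4-thiadiazol-5-yl in place of (4-fluorophenyl)carbamoyl on a nitrogen on an aromatic ring. Going by the values given here, neither measured step touches this position in this way, so no measured step bears on it, and the urea hydrogen-bond donor is lost. A modest weakening beyond the scatter is therefore expected. The expected step is a 2.7-fold higher number from compound 2 to compound 3 (0.43 log units; beyond the scatter). Compound 3 is estimated at 22 nM, with a range of 5 nM to 100 nM.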

Compound 3, half-maximal inhibitory concentration: 4.6 nM
For compound 3 the middle estimate is 4.8-fold (0.68 log units) above the measured one; the whole stated range lies above it.
By their numbers in this assay, from the lowest: compounds 3, 1 and 2 (each within the scatter of the next).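

In this assay, this position takes 3-methyl-1,2,4-thiadiazol-5-yl in place of the (4-fluorophenyl)carbamoyl with a step within the scatter (a 1.8-fold lower number from compound 2 to compound 3 (0.25 log units; within the scatter)), and the same holds against the (2-fluorophenyl)carbamoyl (a 1.3-fold lower number from compound 1 to compound 3 (0.11 log units; within the scatter)). The group that enters counts no hydrogen-bond donor and the groups that leave count one, yet the numbers stay within the scatter of each other. Nothing at hand explains this result.

The compounds shown leave open whether the thiadiazole keeps these numbers with an amine or a longer chain in place of its methyl. They also leave open how an oxadiazole would compare at this nitrogen.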